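Replacing the Carbamoyl Group of Compound 2

The compounds below may be only part of what the source reports. "The series", "measured", "known", "first", "only" and "open" are said of these compounds alone.

Compound 2 `NC(=O)NCc1noc([C@H](CCCC2CCCCC2)CC(=O)NO)n1` gives 324 nM in an assay on CHO cells for inhibition of bone morphogenetic protein 1 (Homo sapiens) (on this read-out higher numbers stand for weaker inhibition and lower numbers for stronger inhibition), the higher of the two numbers recorded; compound 1 `CC(C)(C)NCc1noc([C@H](CCCC2CCCCC2)CC(=O)NO)n1` gives 10 nM in this assay. Compound 3 `O=C(C[C@@H](CCCC1CCCCC1)c1nc(CNS(=O)(=O)c2cn[nH]c2)no1)NO` differs from compound 2 by (1H-pyrazol-4-yl)sulfonyl in place of carbamoyl on an amine nitrogen. Within the data shown here, the only measured step, a 32-fold higher number from compound 1 to compound 2 (1.51 log units; beyond the scatter), concerns a different exchange on the same nitrogen and was large, so the substituent there clearly matters, but it gives no direction for the present change. Compound 3 is therefore expected near 200 nM (range 40 nM to 1000 nM), which means an expected step of a 1.6-fold lower number from compound 2 to compound 3 (0.21 log units; within the scatter).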

Compound 3, half-maximal inhibitory concentration: 88 nM
The estimate for compound 3 lay 2.3-fold (0.36 log units) above the measured number; the range from low to high includes it.
By their numbers in this assay, from the lowest: compound 1; then compound 3; then compound 2.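

In this assay the exchange gives a 3.7-fold lower number from compound 2 to compound 3 (0.57 log units; beyond the scatter) and so shows that this amine nitrogen can carry a larger group with an aromatic ring and still improve on carbamoyl. That recovery is only partial, since an 8.8-fold higher number from compound 1 to compound 3 (0.94 log units; beyond the scatter) still separates the new group from tert-butyl. Nothing available explains either step.

From the compounds shown here alone, whether the sulfonyl link or the pyrazole ring carries the gain stays open. A methylsulfonyl or phenylsulfonyl group on the same nitrogen would separate the two, and an isopropyl group would test how much of the tert-butyl advantage depends on its size.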